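This account rests on a few compounds, and the source may have more. Where it says the series, first, only, none or still open, it means among the compounds named here.

Of the compounds shown here, three built on one shared core have been measured in a functional assay on HEK293 cells for agonist activity at G-protein coupled receptor 39 (Homo sapiens), read by scintillation proximity assay and inositol phosphate accumulation, with a stated time of 75 min; on this read-out lower numbers stand for an effect already at smaller amounts and higher numbers for an effect only at larger amounts of compound. Compound 1 `Cc1nn(-c2ncnc3nc[nH]c23)c2c1C(OC1CCCC1)CC(=O)N2` gives 62 nM, compound 3 `Cc1nn(-c2ncnc3nc[nH]c23)c2c1C(OCc1ccccc1C#N)CC(=O)N2` gives 127 nM, and compound 2 `Cc1nn(-c2ncnc3nc[nH]c23)c2c1C(C(=O)NCc1ccc(F)cc1)CC(=O)N2` gives 1220 nM. Compound 3 thus stands second highest of the three numbers, nearest to compound 1 and furthest from compound 2. Among the measured compounds shown here, the only single-point step measured so far is a 2.0-fold higher number from compound 1 to compound 3 (0.31 log units; beyond the scatter), which alters the group attached through oxygen. Compound 4 `Cc1nn(-c2ncnc3nc[nH]c23)c2c1C(C(=O)NCc1ccccc1)CC(=O)N2` differs from compound 3 by benzylcarbamoyl in place of (2-cyanobenzyl)oxy on a saturated ring carbon. For the measured compounds named here, no measured step covers this exchange directly, but compound 2, whose side chain also attaches through a carbamoyl, gives 1220 nM. A shift toward that value is therefore expected, a 7.9-fold higher number from compound 3 to compound 4 (0.90 log units; beyond the scatter). Compound 4 is estimated at 1000 nM, within 350 nM to 3000 nM.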

Compound 4, half-maximal effective concentration: 2930 nM
Estimate against measurement, compound 4: 2.9-fold (0.47 log units) below, and the stated range covers the measured number.
By their numbers in this assay, from the lowest: compound 1; then compound 3; then compound 2; then compound 4.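

On this saturated ring carbon, benzylcarbamoyl brings a 23-fold higher number from compound 3 to compound 4 (1.36 log units; beyond the scatter) in place of (2-cyanobenzyl)oxy and a 47-fold higher number from compound 1 to compound 4 (1.67 log units; beyond the scatter) in place of cyclopentyloxy, even though the first exchange keeps one six-membered aromatic ring of carbon on both sides. Among the carbamoyl side chains the aromatic ring's substituent also counts, by a smaller step: hydrogen in place of fluoro on an aromatic carbon gives a 2.4-fold higher number from compound 2 to compound 4 (0.38 log units; beyond the scatter) and leaves the fluoro compound with the lower number. Whether an amine or a carboxylic acid on this carbon would fall nearer the oxygen-linked compounds stays open, and nothing at hand speaks to the reason for these steps.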